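Removing one 2,6-dichlorobenzyl group from compound 1

A few compounds are considered here, and "the series" means these few. Any claim that something is new, unique, unknown or untested is made for them only; others in the source may bear on it.

Measured in a functional assay on CNE2Z cells (Homo sapiens) for inhibition, read by MTT assay, with a stated time of 72 h; a higher number here means a weaker inhibitor, a lower number a stronger inhibitor:
- compound 1 `C=CCc1ccc(OCc2c(Cl)cccc2Cl)c(-c2ccc(OCc3c(Cl)cccc3Cl)c(CC=C)c2)c1` gives > 50000 nM
- compound 2 `C=CCc1ccc(OCc2ccc(Cl)c(Cl)c2)c(-c2ccc(OCc3ccc(Cl)c(Cl)c3)c(CC=C)c2)c1` gives > 50000 nM
- compound 3 `C=CCc1ccc(O)c(-c2ccc(OCc3c(Cl)cccc3Cl)c(CC=C)c2)c1` gives 16400 nM

Compound 1 stands at the limit of > 50000 nM in this assay, at which 2 of the 3 values shown sit, and has no numerical value. Compound 2 gives > 50000 nM in this assay and this too is a limit. Compound 4 `C=CCc1ccc(OCc2c(Cl)cccc2Cl)c(-c2ccc(O)c(CC=C)c2)c1` is compound 1 with hydrogen in place of 2,6-dichlorobenzyl on an oxygen on an aromatic ring, as counted in hydrogen in place of 2,6-dichlorobenzyl on an oxygen on an aromatic ring for this change.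

Going by the values given here, the one measured step of this kind is an at least 3.0-fold lower number from compound 1 to compound 3 (0.48 log units; beyond the scatter) in this assay and it is made at the other such oxygen. From the compounds shown here alone, that step starts from a limit and its full size is unknown. Compound 3 gives 16400 nM as its measured endpoint. The same exchange at a different oxygen need not behave identically, so a wide range is warranted, and a further limit reading remains possible. A change of similar size and the same direction is expected here, toward a lower number. The expected step is an at least 3.3-fold lower number from compound 1 to compound 4 (0.52 log units; beyond the scatter) in this assay on this single precedent. Compound 4 is estimated at 15000 nM with an expected range from 6000 nM to 45000 nM in this reading.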

Compound 4, half-maximal inhibitory concentration: 19900 nM
Estimate against measurement, compound 4: 1.3-fold (0.12 log units) below, and the stated range covers the measured number.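

Removing a 2,6-dichlorobenzyl group from compound 1 now gives a measured number at the second oxygen on an aromatic ring: in this assay the result is an at least 2.5-fold lower number from compound 1 to compound 4 (0.40 log units; beyond the scatter). Together with an at least 3.0-fold lower number from compound 1 to compound 3 (0.48 log units; beyond the scatter), this shows that the same exchange moves the number the same way at both oxygens, with both steps beyond the scatter, so the effect is not confined to one oxygen. The two steps share a starting point that is only a limit, so their full sizes remain unknown and they cannot be ranked against each other: the limit of > 50000 nM in this assay, at which 2 of the 4 values shown sit.

Still open, from the compounds shown here alone, is whether the change in this assay depends on the free hydroxy itself or only on the loss of the 2,6-dichlorobenzyl group, a question that a methyl ether or an acetate ester on the same oxygen would help to separate. Also open, going by these compounds, is what the compound carrying hydroxy at both oxygens would give, and whether a benzyl group bearing an amine or a carboxylic acid would behave like 2,6-dichlorobenzyl.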